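This account rests on a few compounds, and the source may have more. Where it says the series, first, only, none or still open, it means among the compounds named here.

Measured compounds in an ADME assay on Raji cells (Homo sapiens) for cytotoxicity, read by luminescence, with a stated time of 72 h; on this read-out lower numbers stand for an effect already at smaller amounts and higher numbers for an effect only at larger amounts of compound:

Compound 1, `CCOC(=O)c1c(-c2cccc(-c3ccccc3)c2)[nH]c2cc(OC)ccc2c1=O`: compound 1 gives > 21500 nM, which is a limit of the assay and not a number.
Compound 2, `CCOC(=O)c1c(-c2cccc(OC)c2)[nH]c2cc(OC)ccc2c1=O`: compound 2 gives > 21500 nM, again a limit of the assay.
Compound 3, `CCOC(=O)c1c(-c2cccc(-c3ccccc3)c2)[nH]c2cc(Cl)c(OC)cc2c1=O`: compound 3 gives > 21500 nM, also a limit of the assay.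

Compound 1 and compound 2 differ in one place: methoxy in place of phenyl on an aromatic carbon. The step that this change made, a step that the two limits leave unreadable from compound 1 to compound 2, cannot be given a size because of the limit of > 21500 nM in this assay, at which 3 of the 3 values shown sit.

Compound 4, `CCOC(=O)c1c(-c2cccc(OC)c2)[nH]c2cc(Cl)c(OC)cc2c1=O`, has not yet been measured in this assay. It stands to compound 3 as compound 2 stands to compound 1: methoxy in place of phenyl on an aromatic carbon, the same change at the same kind of place. How the core of compound 3 differs from the core of compound 1 is not broken down here.

The step from compound 3 to compound 4 in this assay is expected to be a step that the limit leaves unreadable from compound 3 to compound 4, since the earlier step of the same change stayed hidden behind the limit on both sides. For compound 4 in this assay the expected value is 30000 nM, with a range estimated from 15000 nM to 100000 nM.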

Compound 4, half-maximal effective concentration: > 21500 nM
Compound 4: a limit, no number; the forecaster's own chance of this, stated with the estimate: 85%; the middle value is on the limit's open side.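

Compound 3 and compound 4 both sit at a limit of the assay and not at a number, so no size can be read for the change of phenyl to methoxy between them, for this reason: the limit of > 21500 nM in this assay, at which 4 of the 4 values shown sit. The compounds shown leave open whether any of them has an effect at larger amounts in this assay, and whether this change alters that effect.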